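The compounds below may be only part of what the source reports. "The series", "measured", "known", "first", "only" and "open" are said of these compounds alone.

Measured compounds:
compound 1 `Cc1nn(-c2nc(-c3ccc(Cl)c(Cl)c3)c(SC(C)C)s2)c(C(=O)O)c1-c1cnccn1`, 14000 nM in a functional assay on BJAB cells (Homo sapiens) for antiproliferative activity, with a stated time of 4 days; a higher number here means that more compound is needed for the effect, a lower number that less compound is needed
compound 2 `CCOc1ncccc1-c1c(C)nn(-c2nc(-c3ccc(Cl)c(Cl)c3)c(SC(C)C)s2)c1C(=O)O`, 11000 nM
compound 3 `Cc1nn(-c2nc(-c3ccc(Cl)c(Cl)c3)c(SC(C)C)s2)c(C(=O)O)c1-c1cncc(C#N)c1`, 20000 nM

Compound 1 has the second highest of the three numbers in this assay; its steps to both others are within the scatter, so no order among the three can be read. Compound 4 `COc1cc(Cl)cc(-c2c(C)nn(-c3nc(-c4ccc(Cl)c(Cl)c4)c(SC(C)C)s3)c2C(=O)O)c1` differs from compound 1 by 3-chloro-5-methoxyphenyl in place of pyrazin-2-yl on an aromatic carbon. The two steps that bear on it, both replacing pyrazin-2-yl, are a 1.3-fold lower number from compound 1 to compound 2 (0.10 log units; within the scatter) and a 1.4-fold higher number from compound 1 to compound 3 (0.15 log units; within the scatter); neither leaves the scatter. A step of similar size, no larger than the scatter, is therefore expected, no change at the digits printed from compound 1 to compound 4 (within the scatter). Compound 4 is estimated at 14000 nM, with a range from 5000 nM to 40000 nM.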

Compound 4, half-maximal effective concentration: 760 nM
Estimate against measurement, compound 4: 18-fold (1.27 log units) above; measured number below the stated range.
By their numbers in this assay, from the lowest: compound 4; then compounds 2, 1 and 3 (each within the scatter of the next).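

At this position, the three rings with ring nitrogen stayed within the scatter of one another in this assay, but 3-chloro-5-methoxyphenyl, with its ring of carbon only, brings an 18-fold lower number from compound 1 to compound 4 (1.27 log units; beyond the scatter) along with a 14-fold lower number from compound 2 to compound 4 (1.16 log units; beyond the scatter) and a 26-fold lower number from compound 3 to compound 4 (1.42 log units; beyond the scatter) as well. The position is therefore not indifferent to the group it carries. Nothing available explains this change.

Chlorine and methoxy enter together in compound 4, so their separate shares remain unknown. On these data alone, it also remains open whether unsubstituted phenyl, or a phenyl carrying only chlorine or only methoxy, would give a similarly low number.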